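This account rests on a few compounds, and the source may have more. Where it says the series, first, only, none or still open, it means among the compounds named here.

Series values in a functional assay on M21 cells (Homo sapiens) for inhibition, read by sulforhodamine B assay, with a stated time of 48 h; a higher number here means a weaker inhibitor of growth, a lower number a stronger inhibitor of growth:

- compound 1 `c1cc(C2CCCCC2)ccc1NC1=NCCO1`: 17800 nM
- compound 2 `c1cc(NC2=NCCO2)cc(OC2CCCC2)c1`: 76900 nM
- compound 3 `c1ccc(Oc2cccc(NC3=NCCO3)c2)cc1`: 9600 nM

Compound 3, at 9600 nM, sits within the scatter of compound 1, so those two cannot be ranked. It stands clearly apart from the remaining compound, with an 8.0-fold lower number from compound 2 to compound 3 (0.90 log units; beyond the scatter).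

The next compound to be read is compound 4 `O=C(CCl)NC(=O)Nc1cccc(Oc2ccccc2)c1`. Its difference from compound 3 is a group of 7 heavy atoms (3 carbon, 1 nitrogen, 2 oxygen, 1 chlorine; no ring) in place of a group of 5 heavy atoms (3 carbon, 1 nitrogen, 1 oxygen; one five-membered non-aromatic ring with 2 hetero atoms), on a nitrogen on an aromatic ring. The five-membered non-aromatic ring is therefore lost, and an open group with no ring takes its place.

For the measured compounds named here, only one measured step is available, an 8.0-fold lower number from compound 2 to compound 3 (0.90 log units; beyond the scatter). It lies elsewhere in the structure, at the group on an oxygen on an aromatic ring, and it leaves the changing group untouched. Going by the values given here, no measured compound replaces the five-membered ring, so that step offers only a rough guide to how far a single change can move this assay. A move of similar or smaller size is expected, and the lean towards a lower number is a weak one that the data do not settle. The expected change is a 1.9-fold lower number from compound 3 to compound 4 (0.28 log units; within the scatter). For compound 4 the estimated value is 5000 nM, with an expected range from 1500 nM to 17000 nM.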

Compound 4, concentration for 50% growth inhibition: 5300 nM
Estimate against measurement, compound 4: 1.1-fold (0.03 log units) below; low and high end bracket the measured number.
By their numbers in this assay, from the lowest: compounds 4, 3 and 1 (each within the scatter of the next, the first and the last beyond it); then compound 2.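

For the compounds shown here, this is the first reading at the place on a nitrogen on an aromatic ring, and in this assay it gives a 1.8-fold lower number from compound 3 to compound 4 (0.26 log units; within the scatter), so compound 3 and compound 4 cannot be ranked. In this pair, with the phenyl on oxygen held constant, the five-membered non-aromatic ring is therefore not needed to keep the reading in the same range: the open ((chloromethyl)carbonyl)carbamoyl group, with no ring and a hydrogen-bond donor that the ring group lacks, reads alike within the scatter. No measurement on the series speaks to the reason these two different groups read alike.

The compounds shown leave open what the chlorine contributes, and a methyl or a bromomethyl in place of the chloromethyl would separate its part from that of the carbonyl and carbamoyl portion of the group. Also open, going by these compounds, is whether the exchange of the ring for the ((chloromethyl)carbonyl)carbamoyl group reads the same on the cores of compound 1 and compound 2, which carry cyclohexyl and cyclopentyl groups rather than the phenyl on oxygen.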